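A trifluoromethoxy swap in a two-compound antiproliferative series

The source may report more compounds than this note shows. Statements on the series, on what has been measured and on what is new or still open speak of the compounds shown alone.

Compound 1 `CC(O)(CSc1ccc(F)cc1)C(=O)Nc1ccc(S(F)(F)(F)(F)F)cc1` measured 13500 nM
Compound 2 `CC(O)(CSc1ccccc1C(F)(F)F)C(=O)Nc1ccc(S(F)(F)(F)(F)F)cc1` measured 13200 nM

In a functional assay on CWR22R cells (Homo sapiens) for antiproliferative activity, read by propidium iodide staining, with a stated time of 96 h (a higher number here means a weaker inhibitor, a lower number a stronger inhibitor), compound 2 lies within the scatter of compound 1, so the pair has no order. Compound 3 `CC(O)(CSc1ccccc1OC(F)(F)F)C(=O)Nc1ccc(S(F)(F)(F)(F)F)cc1` carries trifluoromethoxy in place of trifluoromethyl on an aromatic carbon ortho to a large group. Going by the values given here, only one measured step bears on this change (a 1.0-fold lower number from compound 1 to compound 2 (0.01 log units; within the scatter)), a swap of a group on a sulfur that stayed within the scatter, so no shift beyond the scatter is expected in this assay here. The expected step (a 1.0-fold lower number from compound 2 to compound 3 (0.01 log units; within the scatter)) is correspondingly small. Compound 3 is estimated at 13000 nM (expected range 6500 nM to 26000 nM).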

Compound 3, half-maximal inhibitory concentration: 15000 nM
Beside the measured number, compound 3's estimate is 1.2-fold (0.06 log units) below it, within the range that was stated.
By their numbers in this assay, from the lowest: compounds 2, 1 and 3 (each within the scatter of the next).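

In this assay, trifluoromethoxy on an aromatic carbon ortho to a large group gives a step within the scatter (a 1.1-fold higher number from compound 2 to compound 3 (0.06 log units; within the scatter)). The earlier step changed the whole group on the sulfur, whereas this one changes only the substituent at this carbon, adding one oxygen and one hydrogen-bond acceptor, and compound 2 and compound 3 still cannot be ordered. Nothing shown accounts for this result. Open, as far as these compounds go, is whether an amine or a carboxylic acid at this carbon would give a step beyond the scatter.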